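The compounds below may be only part of what the source reports. "The series", "measured", "known", "first", "only" and "open" are said of these compounds alone.

Measured so far in a functional assay on SH-SY5Y cells (Homo sapiens) for inhibition, read by sulforhodamine B assay; a higher number here means a weaker inhibitor, a lower number a stronger inhibitor:
- compound 1, `COC(=O)CC/C(C)=C/Cc1c(OC)c(C)c2c(c1OCC#CCN1CCN(c3ccc(C)cc3)CC1)C(=O)OC2`: 37700 nM
- compound 2, `COC(=O)CC/C(C)=C/Cc1c(OC)c(C)c2c(c1OCC#CCN1CCN(C(c3ccccc3)c3ccccc3)CC1)C(=O)OC2`: 23700 nM
- compound 3, `COC(=O)CC/C(C)=C/Cc1c(OC)c(C)c2c(c1OCC#CCN1CCCc3ccccc31)C(=O)OC2`: 9570 nM

Compound 3 stands at the lowest of the three numbers. Compound 2 is nearest, with a higher number that lies beyond the scatter, and compound 1 is furthest, with a higher number again beyond the scatter. The three share the same core and differ only in the group on the saturated chain carbon bound to a triple-bonded carbon.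

Compound 4, `CCCCNc1ccc(CC#CCOc2c(C/C=C(\C)CCC(=O)OC)c(OC)c(C)c3c2C(=O)OC3)cc1`, has not yet been measured in this assay. Relative to compound 3 it carries 4-(butylamino)phenyl in place of 1,2,3,4-tetrahydroquinolin-1-yl on a saturated chain carbon bound to a triple-bonded carbon. Going by the values given here, no pair of measured compounds differs in a single place, so no step of this kind is on record; the expectation rests on the spread of the three numbers and on compound 3 holding the lowest of them.

The step from compound 3 to compound 4 is expected to be a 1.4-fold higher number from compound 3 to compound 4 (0.13 log units; within the scatter), a modest rise that may not clear the scatter. Compound 4 is estimated to give 13000 nM, with a range from 4500 nM to 40000 nM.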

Compound 4, half-maximal inhibitory concentration: 5960 nM
The estimate for compound 4 lay 2.2-fold (0.34 log units) above the measured number; the range from low to high includes it.
By their numbers in this assay, from the lowest: compounds 4 and 3 (each within the scatter of the next); then compounds 2 and 1 (each within the scatter of the next).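

Going by these compounds alone, the step to 4-(butylamino)phenyl in place of 1,2,3,4-tetrahydroquinolin-1-yl is the first single-place change on record in this assay, and it amounts to a 1.6-fold lower number from compound 3 to compound 4 (0.21 log units; within the scatter). At this saturated chain carbon bound to a triple-bonded carbon, the two groups therefore cannot be told apart, although the entering group has no non-aromatic ring and carries a hydrogen-bond donor that the leaving group lacks. No measurement at hand bears on why the two groups read alike.

On these data alone, it remains open what the butyl chain and the amine hydrogen each contribute, which 4-aminophenyl, 4-(dimethylamino)phenyl or 4-(hexylamino)phenyl at the same place would help to separate. Also open, as far as these compounds go, is whether this reading holds with a carboxylic acid in place of the methyl ester.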